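The source may report more compounds than this note shows. Statements on the series, on what has been measured and on what is new or still open speak of the compounds shown alone.

For the measured compounds named here, in an in vitro ADME assay on microsomes from liver (Homo sapiens) for metabolic stability, read by LC-MS, using NADPH, tested at 1 uM (a higher number here means that the compound lasts longer, a lower number that the compound disappears faster), compound 1 `CCN1C(=O)CN(Cc2ccc(-c3cccc(CN4CCCCC4)n3)cc2)C1=O` gives 2 h as the higher of the two numbers so far. Compound 2 `O=C1CN(Cc2ccc(-c3ccc(F)c(CN4CCCCC4)n3)cc2)C(=O)N1CC1CCC1` gives 0.0833 h and differs from compound 1 in more than one place, so the gap between them says little about any single change. Compound 3 `CC(C)N1C(=O)CN(Cc2ccc(-c3cccc(CN4CCCCC4)n3)cc2)C1=O` turns the ethyl of compound 1 into isopropyl through one change (methyl in place of hydrogen on a saturated chain carbon bound to an amide-type nitrogen in a ring and a saturated chain carbon) with methyl in place of hydrogen. Going by the values given here, no measured pair shows this change, so a small drop or none beyond the scatter is expected. The estimated 1.3-fold lower number from compound 1 to compound 3 (0.12 log units; within the scatter) is small and stays within the scatter. For compound 3 the expected half-life is 1.5 h with an estimated range from 0.5 h to 4 h in this measurement.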

Compound 3, half-life: 1.35 h
Compound 3: the middle estimate sits 1.1-fold (0.05 log units) above what was measured, within the range that was stated.
By their numbers in this assay, from the lowest: compound 2; then compounds 3 and 1 (each within the scatter of the next).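

In this assay, methyl in place of hydrogen at this saturated chain carbon, which turns ethyl into isopropyl, gives a 1.5-fold lower number from compound 1 to compound 3 (0.17 log units; within the scatter), so the two compounds cannot be told apart here. For the compounds shown here, this is the first comparison that isolates a single place, which the gap to compound 2 could not do. Nothing measured here explains the result. Going by these compounds, whether tert-butyl or a longer chain such as propyl at this place would also stay within the scatter of compound 1 remains open. So does whether this step would read the same with the fluorine of compound 2 present.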